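The source may report more compounds than this note shows. Statements on the series, on what has been measured and on what is new or still open speak of the compounds shown alone.

Measured in a functional assay on CNE-2 cells (Homo sapiens) for inhibition, read by MTT assay, with a stated time of 72 h; on this read-out higher numbers stand for weaker inhibition and lower numbers for stronger inhibition:
- compound 1 `CNC(=O)CCCCCCCn1nc(-c2cnc3[nH]ccc3c2)c2c(N)ncnc21`: 8990 nM
- compound 2 `Nc1nc2cc(-c3nn(CCCC(=O)NO)c4ncnc(N)c34)ccc2o1`: > 50000 nM (a limit)
- compound 3 `Nc1ncnc2c1c(-c1cnc3[nH]ccc3c1)nn2CCCCCC(=O)NO`: > 50000 nM (a limit)

Compound 2 gives > 50000 nM, and that is a limit of the assay, not a number. It stands at the limit of > 50000 nM in this assay, at which 2 of the 3 values shown sit.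

Compound 4 `Nc1nc2cc(-c3nn(CCCCCCCCCC(=O)NO)c4ncnc(N)c34)ccc2o1` keeps the core of compound 2 but has a longer chain, with 6-(hydroxycarbamoyl)hexyl in place of hydroxycarbamoyl on a saturated chain carbon, three bonds along the chain from an aromatic nitrogen.

For the measured compounds named here, one measured step bears on this change, an at least 5.5-fold higher number from compound 1 to compound 3 (0.74 log units; beyond the scatter). It lies beyond the scatter, and its size is only a minimum. It is an indirect guide, since the chain length and the chain end change together, and compound 1 and compound 3 carry a different group on the core from compound 2 and compound 4. Even so, the one chain longer than that of compound 3 gives a real number, so a longer chain is expected to bring a lower number, meaning stronger inhibition.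

In this assay the expected change is an at least 10-fold lower number from compound 2 to compound 4 (1.00 log units; beyond the scatter).

For compound 4 the estimate is 5000 nM, with an expected range of 600 nM to 40000 nM.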

Compound 4, half-maximal inhibitory concentration: 36800 nM
Estimate against measurement, compound 4: 7.4-fold (0.87 log units) below; measured number inside the range.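

In this assay compound 4 gives 36800 nM, a measured number, so a chain ending in hydroxycarbamoyl can give a readable value at this position, which neither of the shorter hydroxycarbamoyl chains shown had done. Compound 2 gives > 50000 nM, which is a limit of the assay and not a number. Read against that limit, the change is an at least 1.3-fold lower number from compound 2 to compound 4 (0.13 log units; that floor lies within the scatter), so the lengthening may bring a large gain or almost none, and compound 4 remains a weak inhibitor on this read-out.

From the compounds shown here alone, it remains open whether a still longer chain, or one of intermediate length, would lower the number further on this core. Going by these compounds, it is also open how a carboxylic acid at the end of the same chain would compare with hydroxycarbamoyl.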